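The compounds below may be only part of what the source reports. "The series", "measured", "known", "first", "only" and "open" are said of these compounds alone.

Measured compounds:
compound 1 `N#Cc1ccc(Nc2nccc(/C(=N\O)c3ccc4ccccc4c3)n2)cc1` gives 31600 nM
compound 2 `Cc1cc(C)cc(/C(=N/O)c2ccnc(Nc3ccc(C#N)cc3)n2)c1` gives 35900 nM

In an ADME assay on MT4 cells (Homo sapiens) for cytotoxicity, read by MTT assay, with a stated time of 4 days (on this read-out lower numbers stand for higher toxicity in this test and higher numbers for lower toxicity in this test), compound 2 gives 35900 nM and compound 1 gives 31600 nM; the two numbers lie within the scatter of each other, so neither can be called less toxic than the other. Compound 3 `Cc1ccccc1/C(=N/O)c1ccnc(Nc2ccc(C#N)cc2)n1` is not yet measured. Its structure differs from that of compound 2 in one place: 2-methylphenyl in place of 3,5-dimethylphenyl on a carbon with a double bond to nitrogen. Among the compounds with values here, no measured pair shows what such a change does here. Compound 3 is therefore expected to stay close to compound 2 in this assay, with a step of a 1.0-fold lower number from compound 2 to compound 3 (0.01 log units; within the scatter) that should lie within the scatter. The estimate for compound 3 is 35000 nM, with a range from 15000 nM to 80000 nM.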

Compound 3, half-maximal cytotoxic concentration: 29900 nM
For compound 3 the middle estimate is 1.2-fold (0.07 log units) above the measured one; low and high end bracket the measured number.
By their numbers in this assay, from the lowest: compounds 3, 1 and 2 (each within the scatter of the next).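

In this assay, 2-methylphenyl in place of 3,5-dimethylphenyl on a carbon with a double bond to nitrogen gives a 1.2-fold lower number from compound 2 to compound 3 (0.08 log units; within the scatter). This is the first one-place change shown at this position, and it tells that this exchange of one methyl-bearing phenyl group for another does not separate the two compounds on this read-out. As far as these compounds go, whether a phenyl group carrying an amine or a carboxylic acid, or a longer alkyl chain in place of the ring, would move the number beyond the scatter stays open. No available measurement bears on the reason for this result.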